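Butyl on the core of compound 2

A few compounds are considered here, and "the series" means these few. Any claim that something is new, unique, unknown or untested is made for them only; others in the source may bear on it.

In a functional assay on HOS cells (Homo sapiens) for antiproliferative activity, read by sulforhodamine B assay (a higher number here means a weaker inhibitor of growth, a lower number a stronger inhibitor of growth), compound 2 (`O[C@H]1CO[C@H](COCc2ccccc2)[C@@H](OCc2ccccc2)[C@@H]1OCc1ccccc1`) reads 37900 nM and stands within the scatter of the two other measured compounds. Compound 1 (`c1ccc(COC[C@H]2OCC[C@@H](OCc3ccccc3)[C@@H]2OCc2ccccc2)cc1`) reads 22200 nM in the same test, and compound 3 (`CCC[C@H]1O[C@H](COCc2ccccc2)[C@@H](OCc2ccccc2)[C@H](OCc2ccccc2)[C@H]1O`) reads 23600 nM there. Compound 4 (`CCCC[C@@H]1O[C@H](COCc2ccccc2)[C@@H](OCc2ccccc2)[C@H](OCc2ccccc2)[C@H]1O`) differs from compound 2 by one change, butyl in place of hydrogen on a saturated ring carbon.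

The nearest measured precedent is propyl in place of hydrogen on a saturated ring carbon, which gave a 1.6-fold lower number from compound 2 to compound 3 (0.21 log units; within the scatter) as its result. The other measured step, hydroxy in place of hydrogen on a saturated ring carbon, gave a 1.7-fold higher number from compound 1 to compound 2 (0.23 log units; within the scatter) as its result. Neither step leaves the scatter, and a single alkyl example gives no firm trend with chain length. No step beyond the scatter is therefore expected in this assay for butyl. The estimated move is a 1.5-fold lower number from compound 2 to compound 4 (0.18 log units; within the scatter) and stays within the scatter. Compound 4 is estimated at 25000 nM with an expected range from 12000 nM to 45000 nM in this test.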

Compound 4, concentration for 50% growth inhibition: 40100 nM
The estimate for compound 4 lay 1.6-fold (0.21 log units) below the measured number, and the stated range covers the measured number.
By their numbers in this assay, from the lowest: compounds 1, 3, 2 and 4 (each within the scatter of the next).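

In this assay, butyl in place of hydrogen on a saturated ring carbon next to the ring oxygen gives a 1.1-fold higher number from compound 2 to compound 4 (0.02 log units; within the scatter) and leaves the reading within the scatter. Within the data shown here, with the propyl step, a 1.6-fold lower number from compound 2 to compound 3 (0.21 log units; within the scatter), this ring carbon now has two alkyl chains on record, and neither step leaves the scatter, so the single alkyl example is no longer alone and no trend with chain length appears. No available evidence bears on this result.

What the compounds shown leave open is whether a longer chain, an amine or a carboxylic acid on this ring carbon would give a step beyond the scatter. Also open, going by these compounds, is whether butyl would behave the same way on a core carrying a free hydroxy group in place of a benzyloxy group.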